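Trimming one methoxy group on an aryl-triazole series measured for cell-growth inhibition

This account rests on a few compounds, and the source may have more. Where it says the series, first, only, none or still open, it means among the compounds named here.

Compound 1, `COc1ccc(OC)c(-c2cn(-c3ccc(O)c(C(=O)Nc4cccc(C(F)(F)F)c4)c3)nn2)c1`: 46%
Compound 2, `COc1cc(OC)cc(-c2cn(-c3ccc(O)c(C(=O)O)c3)nn2)c1`: 2%

In a functional assay on HCT-116 cells (Homo sapiens) for inhibition, read by MTT assay, with a stated time of 2 days, tested at 10 uM (a lower number here means less inhibition, a higher number more inhibition at the concentration tested (going by the name of the read-out)), compound 1 gives 46%, the higher of the two measured numbers. Compound 2 gives 2%, a gap beyond the usual scatter, though the two compounds differ in several places at once. Compound 3, `COc1ccc(-c2cn(-c3ccc(O)c(C(=O)Nc4cccc(C(F)(F)F)c4)c3)nn2)cc1`, departs from compound 1 in a single place: 4-methoxyphenyl in place of 2,5-dimethoxyphenyl on an aromatic carbon. Going by the values given here, no measured pair shows this change alone, so the step from compound 1 to compound 3 is expected to be modest, with a slight drop in inhibition more likely than a rise: a number 8 percentage points lower from compound 1 to compound 3 (within the scatter). Compound 3 is therefore estimated at 38%, in the range 15% to 58%.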

Compound 3, a percentage reported as inhibition, at one concentration (the size of the read-out at that concentration, not a potency): 9%
Compound 3: middle estimate off by 29 percentage points, on the high side; the whole stated range lies above it.
By their numbers in this assay, from the lowest: compounds 2 and 3 (each within the scatter of the next); then compound 1.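

In this assay, going by these compounds alone, this is the first comparison that changes one place only: 4-methoxyphenyl in place of 2,5-dimethoxyphenyl on the five-membered aromatic ring gives a number 37 percentage points lower from compound 1 to compound 3 (beyond the scatter). The inhibition seen with compound 1 therefore depends strongly on the aryl group at this position, even with the rest of the molecule unchanged. Nothing available explains the drop.

The change both removes a methoxy group and alters the substitution pattern, so the compounds shown cannot separate these two effects. On these data alone, how an ethoxy group or an amine on this phenyl ring would behave remains open.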